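Phenyl in place of isopropyl on a carbonyl carbon

The compounds below may be only part of what the source reports. "The series", "measured", "known", "first", "only" and "open" are said of these compounds alone.

Measured so far in a functional assay on HL-60 cells (Homo sapiens) for antiproliferative activity, read by MTT assay, with a stated time of 48 h (on this read-out lower numbers stand for stronger inhibition and higher numbers for weaker inhibition), for three compounds:
- compound 1 `COC/C1=C/C[C@](C)(CCC=C(C)C)/C=C/[C@@H](OC(=O)C=C(C)C)[C@](C)(O)/C=C/C1=O` gives 3070 nM
- compound 2 `CC(C)=CCC[C@]1(C)/C=C/[C@@H](OC(=O)C=C(C)C)[C@](C)(O)/C=C/C(=O)/C(Cn2cc(CO)nn2)=C\C1` gives 3200 nM
- compound 3 `CC(C)=CCC[C@]1(C)/C=C/[C@@H](OC(=O)C(C)C)[C@](C)(O)/C=C/C(=O)/C(CO)=C\C1` gives 4000 nM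

Compound 3 at 4000 nM lies within the scatter of the other two values, so these compounds cannot be ranked. Compound 4 `CC(C)=CCC[C@]1(C)/C=C/[C@@H](OC(=O)c2ccccc2)[C@](C)(O)/C=C/C(=O)/C(CO)=C\C1` is related to compound 3 by phenyl in place of isopropyl on a carbonyl carbon with phenyl in place of isopropyl on a carbonyl carbon, which reads as isopropylcarbonyl to benzoyl. Going by the values given here, no measured step touches this place. Among the compounds with values here, the only step available is a 1.0-fold higher number from compound 1 to compound 2 (0.02 log units; within the scatter) and it concerns a saturated chain carbon bound to a double-bonded ring carbon. It therefore gives only weak guidance for the carbonyl change in this assay and sets no direction. The estimate stays close to compound 3 with a wide range. The expected step is a 1.1-fold lower number from compound 3 to compound 4 (0.06 log units; within the scatter) and no change beyond the scatter is expected. For compound 4 the estimated value is 3500 nM with an expected range from 1500 nM to 9000 nM in this read-out.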

Compound 4, half-maximal inhibitory concentration: 22600 nM
The estimate for compound 4 lay 6.5-fold (0.81 log units) below the measured number, outside the stated range (above it).
By their numbers in this assay, from the lowest: compounds 1, 2 and 3 (each within the scatter of the next); then compound 4.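

In this assay, going by these compounds alone, the change of isopropylcarbonyl to benzoyl gives a 5.7-fold higher number from compound 3 to compound 4 (0.75 log units; beyond the scatter) and is the only step in this set beyond the scatter, whereas a 1.0-fold higher number from compound 1 to compound 2 (0.02 log units; within the scatter) concerns a different place. This place, on a carbonyl carbon, therefore responds to the group it carries, and for this one pair phenyl reads weaker than isopropyl. No evidence on the origin of this step is available.

Open, going by these compounds, is whether cyclohexyl in this place would read like isopropyl or like phenyl, which would separate the aromatic ring from the larger count of carbons, and whether an amine on the phenyl ring would recover any of the loss. Also open, on these data alone, is whether the same step would hold with methoxy, as in compound 1, on the saturated chain carbon.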